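The source may report more compounds than this note shows. Statements on the series, on what has been measured and on what is new or still open speak of the compounds shown alone.

Of the compounds shown here, three sharing one core have been measured in a functional assay on PC-12 cells (Rattus norvegicus) for cytotoxicity, read by MTT assay, with stated times of 3 h and 2 h, tested at 20 uM; on this read-out lower numbers stand for a weaker effect and higher numbers for a stronger effect at the one concentration tested. Compound 1 `CC(=O)c1cc2ccc(OCCCn3cc(CNC(=O)CCCCC4CCSS4)nn3)cc2oc1=O` gives 39.8% in this assay, compound 2 `O=C(CCCCC1CCSS1)NCc1cn(CCCOc2ccc3cc(C(=O)O)c(=O)oc3c2)nn1` gives 66.8%, and compound 3 `O=C(CCCCC1CCSS1)NCc1cn(CCCOc2ccc3cc(-c4ccccc4)c(=O)oc3c2)nn1` gives 27.2%. Compound 1 thus stands second highest of the three, with a number 27 percentage points higher from compound 1 to compound 2 (beyond the scatter) and a number 12.6 percentage points lower from compound 1 to compound 3 (beyond the scatter). Compound 4 `COc1ccc(-c2cc3ccc(OCCCn4cc(CNC(=O)CCCCC5CCSS5)nn4)cc3oc2=O)cc1` differs from compound 1 in one place: 4-methoxyphenyl in place of acetyl on an aromatic carbon. The step that bears on this is the one placing phenyl in place of acetyl, a number 12.6 percentage points lower from compound 1 to compound 3 (beyond the scatter), a modest fall; the large fall a number 39.6 percentage points lower from compound 2 to compound 3 (beyond the scatter) begins from carboxy and is less comparable. A modest fall is therefore expected for compound 4, a number 10.8 percentage points lower from compound 1 to compound 4 (beyond the scatter). Compound 4 is accordingly estimated at 29%, between 17% and 42%.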

Compound 4, a percentage reported as activity, at one concentration (the size of the read-out at that concentration, not a potency): 62%
For compound 4 the middle estimate is 33 percentage points below the measured one, and the stated range ends below it.
By their numbers in this assay, from the lowest: compound 3; then compound 1; then compounds 4 and 2 (each within the scatter of the next).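

In this assay an aryl group at this position does not of itself lower the number: methoxy in place of hydrogen on the phenyl brings a number 34.8 percentage points higher from compound 3 to compound 4 (beyond the scatter) and turns the fall seen with phenyl into a number 22.2 percentage points higher from compound 1 to compound 4 (beyond the scatter) for 4-methoxyphenyl in place of acetyl. Carboxy is not alone in giving a high number here: 4-methoxyphenyl in its place shows a number 4.8 percentage points lower from compound 2 to compound 4 (within the scatter) on the same core. Going by these compounds, what a hydroxy or an amine in place of the methoxy would give stays open. Nothing shown here explains the rise that comes with the methoxy.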